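Moving the Fluorine Around the Pendant Phenyl Ring

This account rests on a few compounds, and the source may have more. Where it says the series, first, only, none or still open, it means among the compounds named here.

Compound 1 `O=S(=O)(c1cccc(F)c1)c1cnc2c(F)cccc2c1-c1ccccc1F`: 0.21 mL/min
Compound 2 `O=S(=O)(c1cccc(F)c1)c1cnc2c(F)cccc2c1-c1cccc(F)c1`: 1.14 mL/min

In an ADME assay on microsomes from liver (Homo sapiens) for metabolic stability, tested at 2.5 uM (a higher number here means faster removal of the compound, a lower number slower removal), compound 1 gives 0.21 mL/min, while compound 2 gives 1.14 mL/min. For the measured compounds named here, compound 2 therefore stands highest of the two measured numbers, separated from its only neighbour by a 5.4-fold higher number from compound 1 to compound 2 (0.73 log units; beyond the scatter). Compound 3 `O=S(=O)(c1cccc(F)c1)c1cnc2c(F)cccc2c1-c1ccc(F)cc1` is the third member of this small series, and it differs from compound 2 in one place: 4-fluorophenyl in place of 3-fluorophenyl on an aromatic carbon. Going by the values given here, the single measured step concerns a different move of the same fluorine, so it speaks only indirectly to this change; it does show that shifting the fluorine around this ring can move this assay beyond the usual scatter. Among the compounds with values here, with no closer precedent, compound 3 is expected to give a step of a 1.8-fold lower number from compound 2 to compound 3 (0.24 log units; within the scatter), which is taken to lie within the scatter. The estimate for compound 3 is 0.65 mL/min, with a range from 0.2 mL/min to 1.8 mL/min.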

Compound 3, intrinsic clearance in a liver preparation (reported as CLH), per the amount of preparation that the assay uses: 0.19 mL/min
Compound 3: the middle estimate sits 3.4-fold (0.53 log units) above what was measured; measured number below the stated range.
By their numbers in this assay, from the lowest: compounds 3 and 1 (each within the scatter of the next); then compound 2.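

In this assay, the change to 4-fluorophenyl gives a 6.0-fold lower number from compound 2 to compound 3 (0.78 log units; beyond the scatter) and so reverses the direction of the step first seen on this ring. The comparison of the other two isomers gives a 1.1-fold lower number from compound 1 to compound 3 (0.04 log units; within the scatter) and so does not separate 2-fluorophenyl from 4-fluorophenyl, which leaves compound 2, with 3-fluorophenyl, alone at the high end of these three. Across this series, then, the number does not climb or fall steadily as the fluorine moves around the ring; only the 3-fluorophenyl compound stands apart.

Going by these compounds, it remains open whether a different group on this ring, such as a methoxy, a chlorine or an amine, would follow the same positional pattern. Nothing available here explains why compound 2 stands apart from the other two.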